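The source may hold more compounds than are shown below. What is called first, only, known or untested is meant among the compounds shown, and "the series" means these compounds.

Measured so far in a functional assay on HCT-116 cells (Homo sapiens) for cytotoxicity, read by sulforhodamine B assay; a higher number here means that more compound is needed for the effect, a lower number that less compound is needed:
- compound 1 `CCCCCCCCCCCCCCCCCCCCCCCCc1cn([C@@H](CO)[C@H](O)[C@H](O)CCCCCCCCCCCCCC)nn1` gives > 50000 nM as a limit of the assay
- compound 2 `CCCCCCCCCCCCC/C=C/[C@@H](O)[C@H](CO)n1cc(CCC)nn1` gives 16000 nM
- compound 3 `CCCCCCCCCCCCCC[C@@H](O)[C@@H](O)[C@H](CO)n1cc(CCC)nn1` gives 13900 nM

Compound 2 stands at 16000 nM and lies within the scatter of compound 3, which gives 13900 nM here. Compound 4 `CCCCCCCCCCCCC/C=C/[C@@H](O)[C@H](CO)n1cc(CCCCCC)nn1` takes the propyl of compound 2 out to hexyl, with propyl in place of hydrogen on a saturated chain carbon, three bonds along the chain from an aromatic carbon as the counted change: propyl in place of hydrogen on a saturated chain carbon, three bonds along the chain from an aromatic carbon. Within the data shown here, no pair of measured compounds differs in one place, so the series gives no direct size for this change. In this assay no step beyond the scatter is expected, in either direction. The estimated change is a 1.1-fold lower number from compound 2 to compound 4 (0.03 log units; within the scatter) and no larger. Compound 4 is expected at 15000 nM with an estimated range of 6000 nM to 40000 nM as the likely span.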

Compound 4, half-maximal effective concentration: 12500 nM
Compound 4: the middle estimate sits 1.2-fold (0.08 log units) above what was measured; the range from low to high includes it.
By their numbers in this assay, from the lowest: compounds 4, 3 and 2 (each within the scatter of the next). At a limit, above all of these: compound 1.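

In this assay the series now has its first comparison in one place, a 1.3-fold lower number from compound 2 to compound 4 (0.11 log units; within the scatter) and no more. Propyl in place of hydrogen on this saturated chain carbon, three bonds along the chain from an aromatic carbon, therefore leaves the number within the scatter. Compound 2 and compound 4 both give readable numbers, and compound 1 alone stands at a limit: the limit of > 50000 nM in this assay, at which 1 of the 4 values shown sits.

Still open, going by these compounds, is whether a longer chain at this position would move the number beyond the scatter. On these data alone, the effect of an amine or a carboxylic acid at the chain end is also open.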